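Removing a chloro group from an aryl triazene: cytotoxicity

The compounds below may be only part of what the source reports. "The series", "measured", "known", "first", "only" and "open" are said of these compounds alone.

Measured so far:
compound 1 `O=[N+]([O-])c1cccc(/N=N/N2CCCCC2)c1` — > 100000 nM
compound 2 `Clc1ccc(/N=N/N2CCCCC2)cc1` — > 100000 nM
compound 3 `O=[N+]([O-])c1ccc(/N=N/N2CCCC2)cc1` — >= 100000 nM

Three aryl triazenes have been tested in an ADME assay on MT4 cells (Homo sapiens) for cytotoxicity, read by MTT assay, with a stated time of 96 h; on this read-out lower numbers stand for higher toxicity in this test and higher numbers for lower toxicity in this test. None of them gave a number. Compound 1 sits at the limit of > 100000 nM in this assay, at which 2 of the 3 values shown sit, which is a limit of this assay rather than a measured value. Compound 2 stands at the same limit, (the limit of > 100000 nM in this assay, at which 2 of the 3 values shown sit), so all that can be said of it is that its toxicity in this assay was too low to be read. Compound 3 sits at the limit of >= 100000 nM in this assay, at which 1 of the 3 values shown sits, again a limit and not a number. For the measured compounds named here, with every value a limit, no step between measured compounds can be sized, and the three compounds cannot be ordered against one another.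

Compound 4 `c1ccc(/N=N/N2CCCCC2)cc1` is the next compound to be measured in this assay. It differs from compound 2 in one place: hydrogen in place of chloro on an aromatic carbon. Since every measured compound, with or without a substituent on the aromatic ring, sits at the limit, the step is expected to be none beyond the scatter: a number no higher from compound 2 to compound 4 (the limit leaves the size open). Compound 4 is therefore expected to give 100000 nM in this assay, with a likely range from 50000 nM to 200000 nM.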

Compound 4, half-maximal cytotoxic concentration: > 100000 nM
Compound 4: no number, only a limit; the forecaster's own chance of this, stated with the estimate: 80%; the middle value sits exactly at the limit.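

In this assay compound 4 gives > 100000 nM, which is a limit and not a number. For the compounds shown here, compound 1 and compound 2 also stand at limits, so no step from either of them to compound 4 can be read. The compounds shown leave open whether hydrogen in place of chloro or nitro on an aromatic carbon changes cytotoxicity at all.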